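The compounds below may be only part of what the source reports. "The series", "measured", "known", "first", "only" and "open" are said of these compounds alone.

Among the three measured compounds, compound 3, `COc1cc(-c2cc(C(=O)O)c3ccccc3n2)ccc1OCC(=O)Nc1cccc(F)c1`, stands highest in a physicochemical assay for lipophilicity, using the shake flask method, in phosphate buffer, measured as octanol-water partition, at pH 7.4 (a lower number here means a more polar compound, a higher number a more lipophilic compound), with 1.6. Compound 1, `COc1cc(-c2cc(C(=O)O)c3ccccc3n2)ccc1OCC(=O)Nc1cccc(C)c1`, gives 1.5 in this assay, and the difference a number 0.10 log units higher from compound 1 to compound 3 (within the scatter) lies within the scatter. Compound 2, `COc1cc(-c2cc(C(=O)O)c3ccccc3n2)ccc1OCC(=O)Nc1ccc(C)cc1`, gives 1.2, and the step of a number 0.40 log units higher from compound 2 to compound 3 (beyond the scatter) is the only one beyond the scatter. The remaining step, a number 0.30 log units lower from compound 1 to compound 2 (within the scatter), is likewise small.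

Compound 4, `CCCCCCNC(=O)COc1ccc(-c2cc(C(=O)O)c3ccccc3n2)cc1OC`, differs from compound 3 in one place: hexyl in place of 3-fluorophenyl on an amide-type nitrogen. None of the three measured steps concerns this kind of change; each of them swaps one substituent of the aromatic ring on the amide-type nitrogen for another, and all of them stayed small. The replacement of an aromatic ring by a chain on the same nitrogen is therefore not covered by any measured step, and the expectation for compound 4 rests on the change itself rather than on a matching precedent.

Compound 4 is expected to give 2.4 in this assay, within a range of 1.8 to 3. The step of a number 0.80 log units higher from compound 3 to compound 4 (beyond the scatter) is estimated to be larger than any of the measured ones and to run upward.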

Compound 4, distribution coefficient: 1
For compound 4 the middle estimate is 1.40 log units above the measured one, and the stated range ends above it.
By their numbers in this assay, from the lowest: compounds 4, 2, 1 and 3 (each within the scatter of the next, the first and the last beyond it).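

In this assay, hexyl on the amide-type nitrogen removes the aromatic ring altogether, a kind of change that the swaps among ring substituents did not test, and the result is a number 0.60 log units lower from compound 3 to compound 4 (beyond the scatter) and a number 0.50 log units lower from compound 1 to compound 4 (beyond the scatter). Against 4-methylphenyl the same replacement gives a number 0.20 log units lower from compound 2 to compound 4 (within the scatter), so compound 2 goes against a drop across all three ring-bearing compounds, and the size of the step depends on which aromatic group hexyl replaces. Since the same number of carbons leaves with 3-fluorophenyl as enters with hexyl, carbon count alone does not set the number at this position.

Nothing available explains the direction of this step. On these data alone, whether a shorter or longer chain, or a hexyl chain ending in an amine or a carboxylic acid, would follow compound 4 remains open.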